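Tert-butyl for ethyl on the aniline ring of compound 3

A few compounds are considered here, and "the series" means these few. Any claim that something is new, unique, unknown or untested is made for them only; others in the source may bear on it.

Measured so far:
compound 1, `Oc1nc2nonc2nc1Nc1ccc(OCc2ccccc2)cc1`: 2400 nM
compound 2, `Oc1nc2nonc2nc1Nc1ccc(S(F)(F)(F)(F)F)cc1`: 3900 nM
compound 3, `CCc1ccc(Nc2nc3nonc3nc2O)cc1`: 10700 nM

These three compounds share one core and differ only in the group on the outer aromatic ring. Measured in an assay on mitochondria from L6 cells (Rattus norvegicus) for activation, with a stated time of 90 min (on this read-out higher numbers stand for an effect only at larger amounts of compound and lower numbers for an effect already at smaller amounts), compound 3 gives the highest number of the three: the step of a 4.5-fold higher number from compound 1 to compound 3 (0.65 log units; beyond the scatter) and the step of a 2.7-fold higher number from compound 2 to compound 3 (0.44 log units; beyond the scatter) both run towards compound 3, while the step of a 1.6-fold higher number from compound 1 to compound 2 (0.21 log units; within the scatter) stays within the scatter.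

Compound 4, `CC(C)(C)c1ccc(Nc2nc3nonc3nc2O)cc1`, has not yet been measured. Compared with compound 3, (tert-butyl in place of ethyl on an aromatic carbon). The two steps that bear on this are the ones into compound 3: each time the group at this place shrank to ethyl, the number in this assay rose by a modest amount. Tert-butyl is larger than ethyl, so a modest move back down is expected, though neither step involves tert-butyl itself.

For compound 4 a value of about 6000 nM is estimated, with a range from 2500 nM to 15000 nM. This estimate means an expected step of a 1.8-fold lower number from compound 3 to compound 4 (0.25 log units; within the scatter).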

Compound 4, half-maximal effective concentration: 3900 nM
Beside the measured number, compound 4's estimate is 1.5-fold (0.19 log units) above it; measured number inside the range.
By their numbers in this assay, from the lowest: compounds 1, 2 and 4 (each within the scatter of the next); then compound 3.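

Swapping ethyl for tert-butyl gives a 2.7-fold lower number from compound 3 to compound 4 (0.44 log units; beyond the scatter) and shows that a change between two groups of carbon alone, neither with a ring or any hydrogen-bond donors or acceptors, is enough to move the number at this place. Compound 4 also lines up with two very different groups, with no change at the digits printed from compound 2 to compound 4 (within the scatter) against the group of five fluorines and one sulfur and a 1.6-fold higher number from compound 1 to compound 4 (0.21 log units; within the scatter) against benzyloxy, so among these four compounds ethyl alone stands apart. Nothing shown gives a reason for this.

The compounds shown do not tell whether isopropyl or a longer chain such as butyl would sit with ethyl or with tert-butyl. They also leave open what an amine or a carboxylic acid would do at this place.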